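The compounds below may be only part of what the source reports. "The series", "measured", "known", "first", "only" and "open" are said of these compounds alone.

Compound 1 `c1c[nH]c(CN2CCN(CCCc3c[nH]c4ccc(-n5cnnc5)cc34)CC2)n1` gives the lowest number of the two single values in an assay on CHO cells for displacement of a labelled ligand from 5-hydroxytryptamine receptor 1B (Homo sapiens) (a higher number here means a weaker inhibitor, a lower number a stronger inhibitor), where compound 1 shows 36 nM. Compound 3 `CN1CCN(CCCCc2c[nH]c3ccc(-n4cnnc4)cc23)CC1` gives 5100 nM in this assay, far above it and well beyond the scatter. Compound 2 `NC(=O)C(c1ccccc1)N1CCN(CCCc2c[nH]c3ccc(-n4cnnc4)cc23)CC1` has two entries in this assay, 55 nM; 13 nM (2 entries), and their spread is itself worth noting (the several entries of compound 2 in this assay, 55 nM; 13 nM (2 entries)).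

Compound 4 `c1ccc(N2CCN(CCCc3c[nH]c4ccc(-n5cnnc5)cc34)CC2)cc1` differs from compound 1 by one change: phenyl in place of (1H-imidazol-2-yl)methyl on an amine nitrogen in a ring. For the measured compounds named here, no measured pair shows this change, so the step from compound 1 to compound 4 can only be estimated; a modest weakening is expected, close to the scatter, as a 1.7-fold higher number from compound 1 to compound 4 (0.22 log units; within the scatter). Compound 4 is therefore expected to give 60 nM in this assay, within a range from 12 nM to 300 nM.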

Compound 4, half-maximal inhibitory concentration: 13 nM
Compound 4: the middle estimate sits 4.6-fold (0.66 log units) above what was measured; the measured number falls inside the stated range.
By their numbers in this assay, from the lowest: compound 4; then compound 1; then compound 3.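

In this assay, phenyl in place of (1H-imidazol-2-yl)methyl on this amine nitrogen gives a 2.8-fold lower number from compound 1 to compound 4 (0.44 log units; beyond the scatter), so on this pair the hydrogen-bond donor and acceptor of the leaving group are not needed for a low number. The step is modest, and entries for a single compound can themselves lie apart: the several entries of compound 2 in this assay, 55 nM; 13 nM (2 entries)

On these data alone, whether the lower number holds for a phenyl carrying a methoxy group or a fluorine, or for a pyridine ring in the same place, stays open. So does whether benzyl would behave like phenyl.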